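Series notes: pyridyl ether variation, solubility

The source may report more compounds than this note shows. Statements on the series, on what has been measured and on what is new or still open speak of the compounds shown alone.

Compound 3 `Cn1c(COc2cccc(C(=O)O)c2)nc2ccc(Oc3cccc(Cl)n3)cc21` gives 7.7 ug/mL in a physicochemical assay for solubility, read by HPLC, measured as thermodynamic solubility, with a stated time of 4 h, at pH 6.8 (a higher number here means a more soluble compound, a lower number a less soluble compound), the lowest of the three numbers measured; compound 2 `Cn1c(COc2cccc(C(=O)O)c2)nc2cnc(Oc3ccc4c(c3)CCC4)cc21` gives 70 ug/mL and compound 1 `Cn1c(COc2cccc(C(=O)O)c2)nc2cnc(Oc3ccc4c(c3)OCC4)cc21` gives 79 ug/mL, both beyond the scatter above compound 3. Compound 4 `Cn1c(COc2cccc(C(=O)O)c2)nc2ccc(Oc3ncccc3F)cc21` carries 3-fluoropyridin-2-yl in place of 6-chloropyridin-2-yl on an oxygen on an aromatic ring. Among the compounds with values here, the only step measured so far, a 1.1-fold lower number from compound 1 to compound 2 (0.05 log units; within the scatter), concerns a different part of the molecule and lies within the scatter, so no measured step bears directly on the exchange of one halopyridyl group for another. Within the data shown here, with no relevant precedent, compound 4 is expected to stay near compound 3, a 1.3-fold higher number from compound 3 to compound 4 (0.11 log units; within the scatter), with no change beyond the scatter anticipated. Compound 4 is therefore estimated at 10 ug/mL in this assay, within a range from 4 ug/mL to 25 ug/mL.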

Compound 4, solubility: 7.1 ug/mL
Compound 4: the middle estimate sits 1.4-fold (0.15 log units) above what was measured; the measured number falls inside the stated range.
By their numbers in this assay, from the lowest: compounds 4 and 3 (each within the scatter of the next); then compounds 2 and 1 (each within the scatter of the next).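

On an oxygen on an aromatic ring, 3-fluoropyridin-2-yl in place of 6-chloropyridin-2-yl gives in this assay a 1.1-fold lower number from compound 3 to compound 4 (0.04 log units; within the scatter), the first step read at this position. Changing both the halogen and its place on the pyridine ring therefore does not separate these two compounds in this read-out. Nothing at hand gives a cause for this result.

The separate contributions of the halogen and its place on the ring remain unresolved. Also open, on these data alone, is whether a pyridine ring carrying an amine or a morpholine at this position would give a step beyond the scatter.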